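The source may report more compounds than this note shows. Statements on the series, on what has been measured and on what is new or still open speak of the compounds shown alone.

Within the data shown here, in a functional assay on MKN-45 cells (Homo sapiens) for cytotoxicity (on this read-out lower numbers stand for stronger inhibition and higher numbers for weaker inhibition), compound 1 `COc1ccc(S(=O)(=O)N2CCc3cccc(NC(=O)c4ccncc4)c32)cc1` gives 8.8 nM, the lowest of the three numbers so far. Compound 3 `COc1ccc(S(=O)(=O)N2CCc3cccc(NC(=O)c4cccs4)c32)cc1` gives 31 nM, and compound 2 `COc1ccc(C(=O)Nc2cccc3c2N(S(=O)(=O)c2ccc(OC)cc2)CC3)cc1` gives 1600 nM. The measured steps are a 3.5-fold higher number from compound 1 to compound 3 (0.55 log units; beyond the scatter) and a 180-fold higher number from compound 1 to compound 2 (2.26 log units; beyond the scatter). Compound 4 `COc1ccc(S(=O)(=O)N2CCc3cccc(NC(=O)N(C)c4ccccc4)c32)cc1` has not been measured; it differs from compound 1 by methyl(phenyl)amino in place of pyridin-4-yl on a carbonyl carbon. Both measured steps also replace the pyridin-4-yl, and both raise the number; the change to a carbon-only ring without a hydrogen-bond acceptor resembles most closely the large step of a 180-fold higher number from compound 1 to compound 2 (2.26 log units; beyond the scatter). For compound 4 in this assay a large step upward, a 57-fold higher number from compound 1 to compound 4 (1.75 log units; beyond the scatter), is therefore expected. Compound 4 is estimated at 500 nM, with a range from 50 nM to 5000 nM.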

Compound 4, half-maximal inhibitory concentration: > 10000 nM
Compound 4 was reported as a limit; the forecaster's own chance of this, stated with the estimate: 10%; middle value at least 20-fold (1.30 log units) away from the limit.
By their numbers in this assay, from the lowest: compound 1; then compound 3; then compound 2. At a limit, above all of these: compound 4.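

In this assay compound 4 gives > 10000 nM, which is a limit of the assay and not a number. On this carbonyl carbon, the change from (pyridin-4-yl)carbonyl to methyl(phenyl)carbamoyl gives an at least 1100-fold higher number from compound 1 to compound 4 (3.05 log units; beyond the scatter), and the other steps are an at least 320-fold higher number from compound 3 to compound 4 (2.50 log units; beyond the scatter) and an at least 6.2-fold higher number from compound 2 to compound 4 (0.79 log units; beyond the scatter). The position therefore admits a loss beyond even that seen with the 4-methoxyphenyl of compound 2.

From the compounds shown here alone, the true size of these steps stays unknown past the limit. Going by these compounds, it also remains open whether phenylamino, without the methyl, or pyridin-3-yl would stay close to compound 1.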